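Furan-2-yl carbonyl variant in the trimethoxyphenyl series

The source may hold more compounds than are shown below. What is called first, only, known or untested is meant among the compounds shown, and "the series" means these compounds.

Compound 3 `COc1cc(-c2nnc3n2NC(c2ccco2)C(C(=O)c2ccc(C)cc2)S3)cc(OC)c1OC` in a functional assay on MCF7 cells (Homo sapiens) for cytotoxicity, read by MTT assay, with a stated time of 48 h (a higher number here means a weaker inhibitor, a lower number a stronger inhibitor), gives only a limit, > 100000 nM. Compound 1 `COc1cc(-c2nnc3n2NC(c2ccco2)C(C(=O)c2ccccc2F)S3)cc(OC)c1OC` gives 94800 nM in this assay, and compound 2 `COc1cc(-c2nnc3n2NC(c2cccs2)C(C(=O)c2ccc(C)cc2)S3)cc(OC)c1OC` gives 28400 nM. The step of an at least 1.0-fold higher number from compound 1 to compound 3 (0.02 log units; that floor lies within the scatter) lies within the scatter, whereas an at least 3.5-fold higher number from compound 2 to compound 3 (0.54 log units; beyond the scatter) lies beyond it; both steps run into the limit (the limit of > 100000 nM in this assay, at which 1 of the 3 values shown sits). Compound 4 `COc1cc(-c2nnc3n2NC(c2ccco2)C(C(=O)c2ccco2)S3)cc(OC)c1OC` differs from compound 3 by furan-2-yl in place of 4-methylphenyl on a carbonyl carbon. Within the data shown here, only the step from compound 1 to compound 3 changes the group on the carbonyl carbon, and that step stayed within the scatter, so no change beyond the scatter is expected in this assay, with the limit again likely. Compound 4 is expected at 110000 nM (range 40000 nM to 300000 nM) in this assay. The expected step is a step that the limit leaves unreadable from compound 3 to compound 4.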

Compound 4, half-maximal inhibitory concentration: > 100000 nM
Compound 4 gave a limit, no number; the forecaster's own chance of this, stated with the estimate: 55%; the middle value does not contradict the limit.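

In this assay compound 4 gives only a limit, > 100000 nM. A five-membered furan-2-yl on the carbonyl carbon therefore leaves the series at the same limit as 4-methylphenyl, so the change between them cannot be read: the limit of > 100000 nM in this assay, at which 2 of the 4 values shown sit. Against the 2-fluorophenyl group, the only readable step is an at least 1.0-fold higher number from compound 1 to compound 4 (0.02 log units; that floor lies within the scatter).

On these data alone, whether any group on the carbonyl carbon separates these compounds while furan-2-yl stays on the saturated ring carbon remains open. A carbonyl-linked 4-aminophenyl or a carboxylic acid on that phenyl ring would test this.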